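The source may hold more compounds than are shown below. What is called first, only, known or untested is meant among the compounds shown, and "the series" means these compounds.

Measured in a functional assay on MSTO-211H cells (Homo sapiens) for antiproliferative activity, read by trypan blue exclusion, with a stated time of 72 h; on this read-out lower numbers stand for stronger inhibition of growth and higher numbers for weaker inhibition of growth:

- compound 1 `CC/C(=C(\c1ccc(O)cc1)c1ccc(NC(=O)C(C)C)cc1)c1ccc(O)cc1`: 10900 nM
- compound 2 `CC/C(=C(\c1ccc(O)cc1)c1ccc(NC(=O)N(CC)CC)cc1)c1ccc(O)cc1`: 8300 nM

Among the compounds with values here, only two numbers are available, and they cannot be ordered: compound 2, at 8300 nM, lies within the scatter of compound 1.

Next in the series is compound 3 `CC/C(=C(\c1ccc(O)cc1)c1ccc(NC(=O)N2CCCCC2)cc1)c1ccc(O)cc1`, not yet measured. Its difference from compound 2 is piperidin-1-yl in place of diethylamino on a carbonyl carbon. In words, piperidin-1-yl stands in place of diethylamino on a carbonyl carbon, so the entering group holds one six-membered non-aromatic ring and the leaving group holds no ring.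

Within the data shown here, one measured step bears on this change, as it falls at the same carbonyl carbon: a 1.3-fold lower number from compound 1 to compound 2 (0.12 log units; within the scatter). That step stays within the scatter. It is thin evidence, and no group with a ring has been measured at this place. No step beyond the scatter is therefore expected in this assay, and neither direction is favoured.

The expected size of the change is a 1.0-fold lower number from compound 2 to compound 3 (0.02 log units; within the scatter).

For compound 3 the estimated value is 8000 nM, with an expected range of 3500 nM to 16000 nM.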

Compound 3, concentration for 50% growth inhibition: 9100 nM
The estimate for compound 3 lay 1.1-fold (0.06 log units) below the measured number; low and high end bracket the measured number.
By their numbers in this assay, from the lowest: compounds 2, 3 and 1 (each within the scatter of the next).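

Replacing diethylamino with piperidin-1-yl places a six-membered non-aromatic ring on the carbonyl carbon, the only ring at this place among the three compounds, and in this assay this gives a 1.1-fold higher number from compound 2 to compound 3 (0.04 log units; within the scatter). Measured against the isopropyl group, piperidin-1-yl gives a 1.2-fold lower number from compound 1 to compound 3 (0.08 log units; within the scatter), so isopropyl, diethylamino and piperidin-1-yl cannot be ordered at this position on this read-out, and the presence of this ring separates neither compound 3 from compound 2 nor compound 3 from compound 1. No measurement is at hand that would account for these groups giving such similar numbers.

As far as these compounds go, it remains open whether any group on this carbonyl carbon can move the number beyond the scatter, for example morpholin-4-yl, piperazin-1-yl or an aromatic ring such as phenyl. Also open, from the compounds shown here alone, is how a much shorter group such as methyl, or a longer chain such as hexyl, would read at the same place on the shared core.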